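From 3-fluorophenyl to 2-fluorophenyl: a small swap

The source may hold more compounds than are shown below. What is called first, only, known or untested is meant among the compounds shown, and "the series" means these compounds.

In a functional assay on KYSE-410 cells (Homo sapiens) for antiproliferative activity, read by MTT assay, with a stated time of 72 h (a lower number here means a stronger inhibitor, a higher number a weaker inhibitor), compound 1 `CC(C)(C)c1ccc(-c2ccc3c(C(=O)Nc4cccc(F)c4)cc(=O)[nH]c3c2)cc1` gives only a limit of > 20000 nM and no true number. Among the measured compounds shown here, compound 2 `O=C(Nc1cccc(F)c1)c1cc(=O)[nH]c2cc(-c3cccc(F)c3)ccc12` gives 10900 nM as the only true number so far. Compound 3 `O=C(Nc1cccc(F)c1)c1cc(=O)[nH]c2cc(-c3ccccc3F)ccc12` is still unmeasured and has the same atoms as compound 2 joined differently (2-fluorophenyl in place of 3-fluorophenyl on an aromatic carbon) with 2-fluorophenyl in place of 3-fluorophenyl on an aromatic carbon. For the measured compounds named here, the one measured step bearing on this is an at least 1.8-fold lower number from compound 1 to compound 2 (0.26 log units; that floor lies within the scatter) where 3-fluorophenyl replaced 4-(tert-butyl)phenyl on an aromatic carbon, and even its floor lies within the scatter, so it sets no size to carry over. No step beyond the scatter is expected in this assay so the estimated change is a 1.1-fold lower number from compound 2 to compound 3 (0.04 log units; within the scatter) with no firm direction. Compound 3 is expected at 10000 nM with an estimated range from 5000 nM to 20000 nM in this measurement.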

Compound 3, half-maximal inhibitory concentration: > 20000 nM
Compound 3: no number, only a limit (the forecaster's own chance of this, stated with the estimate: 15%); at least 2.0-fold (0.30 log units) between middle value and limit.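

In this assay, moving the fluorine from 3-fluorophenyl to 2-fluorophenyl changes no atom count, yet it brings no lower number: the swap gives an at least 1.8-fold higher number from compound 2 to compound 3 (0.26 log units; that floor lies within the scatter). Compound 3 gives a limit and not a true number, so this floor does not establish a real loss, and compound 2 remains the only compound shown with a true number. The step between compound 1 and compound 3 cannot be read, and any reading of this position stays weak because most results are limits: the limit of > 20000 nM in this assay, at which 2 of the 3 values shown sit.

From the compounds shown here alone, it remains open how far past its limit compound 3 truly lies. Also open, going by these compounds, is whether a plain phenyl, or a phenyl carrying an amine or a carboxylic acid, would give a true number at this position.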